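Will compound 4 last as long as compound 1?

A few compounds are considered here, and "the series" means these few. Any claim that something is new, unique, unknown or untested is made for them only; others in the source may bear on it.

Compound 1 `NCc1ccc(C(=O)Nc2ccncc2F)cc1-c1cccc(NC(=O)c2cccc(C(=O)O)c2)c1` gives > 2 h in an ADME assay on a cell-free system (plasma, Homo sapiens) for metabolic stability, read by LC-MS (a higher number here means that the compound lasts longer, a lower number that the compound disappears faster), a limit and not a number. Compound 1 therefore sits at the limit of > 2 h in this assay, at which 2 of the 3 values shown sit. Compound 3 `NCc1ccc(C(=O)Nc2ccncc2F)cc1-c1cccc(C(=O)Nc2ccccc2)c1` gives > 2 h, also a limit. Compound 2 `COC(=O)c1cccc(NC(=O)c2cccc(-c3cc(C(=O)Nc4ccncc4F)ccc3CN)c2)c1F` gives < 0.0834 h, a limit at the opposite end. Compound 4 `COC(=O)c1ccc(F)c(C(=O)Nc2cccc(-c3cc(C(=O)Nc4ccncc4F)ccc3CN)c2)c1` has 2-fluoro-5-(methoxycarbonyl)phenyl in place of 3-carboxyphenyl on a carbonyl carbon. The measured step that the two limits leave unreadable from compound 1 to compound 3 gives no guide. Compound 2 also carries a methoxycarbonyl group, and its large step of an at least 23-fold higher number from compound 2 to compound 3 (1.37 log units; beyond the scatter) is the closest guide, read in reverse. A large fall in this assay is therefore expected, with the estimated step being an at least 20-fold lower number from compound 1 to compound 4 (1.30 log units; beyond the scatter). For compound 4 the expected half-life is 0.1 h, with an estimated range of 0.04 h to 0.5 h.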

Compound 4, half-life: 0.883 h
For compound 4 the middle estimate is 8.8-fold (0.95 log units) below the measured one, outside the stated range (above it).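

In this assay, replacing 3-carboxyphenyl with 2-fluoro-5-(methoxycarbonyl)phenyl on the carbonyl carbon gives an at least 2.2-fold lower number from compound 1 to compound 4 (0.35 log units; beyond the scatter). The earlier compounds shown here gave only limits, whereas compound 4 gives a true number, so a change at this place now has a readable minimum size. The true size stays unknown, since compound 1 sits at a limit of the assay: the limit of > 2 h in this assay, at which 2 of the 4 values shown sit.

The compounds shown do not separate the fluorine from the methoxycarbonyl group, so which of the two goes with the fall remains open. From the compounds shown here alone, how a primary carboxamide would behave in place of the methoxycarbonyl group is also open.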